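This account rests on a few compounds, and the source may have more. Where it says the series, first, only, none or still open, it means among the compounds named here.

Of the compounds shown here, two built on one shared core have been measured so far in a functional assay on HepG2 cells (Homo sapiens) for cytotoxicity, read by MTT assay, with a stated time of 72 h; a lower number here means a stronger inhibitor, a higher number a weaker inhibitor. Compound 1 `CN1[C@@H]2c3[nH]c4ccccc4c3C[C@H]1[C@H](C#N)N1[C@@H](CNC(=O)c3cccc(C(F)(F)F)c3)c3[nH]c4ccccc4c3C[C@@H]21` gives 340 nM. Compound 2 `CN1[C@@H]2c3[nH]c4ccccc4c3C[C@H]1[C@H](C#N)N1[C@@H](CNC(=O)c3ccc4ccccc4n3)c3[nH]c4ccccc4c3C[C@@H]21`, which differs only in the group attached to the carbonyl carbon of the amide, gives 110 nM. For the measured compounds named here, that single swap produced a 3.1-fold lower number from compound 1 to compound 2 (0.49 log units; beyond the scatter), so compound 2 holds the lower of the two numbers known, with compound 1 the only comparison.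

Compound 3 `CN1[C@@H]2c3[nH]c4ccccc4c3C[C@H]1[C@H](C#N)N1[C@@H](CNC(=O)c3cc4ccccc4s3)c3[nH]c4ccccc4c3C[C@@H]21` has not yet been measured. Its difference from compound 2 is 1-benzothiophen-2-yl in place of quinolin-2-yl on a carbonyl carbon. Going by the values given here, the only measured step at this position is the one from compound 1 to compound 2, and it concerned a different pair of groups, so it offers a loose guide at best: a bicyclic aromatic group is kept, but the ring nitrogen is exchanged for a sulfur in a five-membered ring. From this, the step from compound 2 to compound 3 is expected to be small, a 1.6-fold higher number from compound 2 to compound 3 (0.21 log units; within the scatter), likely within or only slightly beyond the scatter. Compound 3 is therefore estimated at 180 nM, with a plausible range from 70 nM to 450 nM.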

Compound 3, half-maximal inhibitory concentration: 300 nM
The estimate for compound 3 lay 1.7-fold (0.22 log units) below the measured number; the measured number falls inside the stated range.
By their numbers in this assay, from the lowest: compound 2; then compounds 3 and 1 (each within the scatter of the next).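

In this assay, 1-benzothiophen-2-yl in place of quinolin-2-yl gives a 2.7-fold higher number from compound 2 to compound 3 (0.44 log units; beyond the scatter) and shows that keeping two fused aromatic rings on the carbonyl carbon does not by itself preserve the number of compound 2. Against the single-ring 3-(trifluoromethyl)phenyl group, the same 1-benzothiophen-2-yl group gives a 1.1-fold lower number from compound 1 to compound 3 (0.05 log units; within the scatter) and so leaves compound 3 and compound 1 within the scatter of each other, which means that a second ring alone does not separate them. No measurement on these compounds gives a reason for these differences.

Still open, on these data alone, is whether the nitrogen of quinolin-2-yl matters, which naphthalen-2-yl, with two rings of carbon only, or pyridin-2-yl, with a single nitrogen-bearing ring, could help to show. Also open, as far as these compounds go, is how an amine or a carboxylic acid on the ring would affect the number at this position.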